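The source may report more compounds than this note shows. Statements on the series, on what has been measured and on what is new or still open speak of the compounds shown alone.

Working notes on a physicochemical assay for solubility, at pH 7.4 (a lower number here means a less soluble compound, a higher number a more soluble compound), for the series. Compound 2 (`NS(=O)(=O)c1ccc(SCCO)c([N+](=O)[O-])c1`) reads 500 ug/mL and sits at the low end of the three numbers in hand. Compound 3 (`NS(=O)(=O)c1ccc(S(=O)(=O)CCCO)c([N+](=O)[O-])c1`) reads 800 ug/mL and lies within the scatter of compound 2, while compound 1 (`NS(=O)(=O)c1ccc(SCCO)c(F)c1`) reads 6000 ug/mL and stands well clear of both.

The next compound is compound 4 (`NS(=O)(=O)c1ccc(SCCO)c(C(=O)O)c1`), with carboxy in place of nitro on an aromatic carbon ortho to a (2-hydroxyethyl)sulfanyl group (carboxy in place of nitro on an aromatic carbon) and meta to a sulfamoyl group. Among the measured compounds shown here, one measured step bears on this carbon: a 12-fold lower number from compound 1 to compound 2 (1.08 log units; beyond the scatter) for nitro in place of fluoro, a large move. Compound 3 differs from compound 2 in more than one place, so it offers no clean comparison. For the measured compounds named here, no measured compound carries carboxy, and the size of the next step stays uncertain.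

With nitro leaving, an upward step of similar order is expected, resting on compound 1 at 6000 ug/mL and its distance from compound 2. The estimated move is a 10-fold higher number from compound 2 to compound 4 (1.00 log units; beyond the scatter) as a working figure. For compound 4 the expected value is 5000 ug/mL with an estimated range from 1200 ug/mL to 20000 ug/mL for now.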

Compound 4, solubility: 9300 ug/mL
The estimate for compound 4 lay 1.9-fold (0.27 log units) below the measured number; measured number inside the range.
By their numbers in this assay, from the lowest: compounds 2 and 3 (each within the scatter of the next); then compounds 1 and 4 (each within the scatter of the next).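

At this aromatic carbon, ortho to a (2-hydroxyethyl)sulfanyl group and meta to a sulfamoyl group, carboxy in place of nitro gives in this assay a 19-fold higher number from compound 2 to compound 4 (1.27 log units; beyond the scatter), although the two groups match in heavy atoms and in double bonds outside aromatic rings. Against fluoro, the same carbon gives a 1.6-fold higher number from compound 1 to compound 4 (0.19 log units; within the scatter), so carboxy and fluoro cannot be told apart here, and of the three groups seen at this position only nitro stands apart, now by two large steps on the same core rather than one. No measurement in hand explains why nitro separates from the other two groups.

Three groups at one carbon on one core cannot show whether the low reading is particular to nitro or extends to other groups, and an amine, a methyl ester or a primary carboxamide at this position would test that. On these data alone, whether carboxy or fluoro would hold the same relation to nitro with the 3-hydroxypropylsulfonyl chain of compound 3 also remains open, as does any reading of that chain alone, since compound 3 differs from the others in more than one place.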